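Changing Methyl Position on the Pyridine of Compound 2

The source may hold more compounds than are shown below. What is called first, only, known or untested is meant among the compounds shown, and "the series" means these compounds.

Compound 1 `Cc1ccc([C@@H](C)Oc2cc3onc(CCC(=O)O)c3cc2Cl)nc1`: 3.16 nM
Compound 2 `Cc1ccnc([C@@H](C)Oc2cc3oc(=O)n(CCC(=O)O)c3cc2Cl)c1`: 3.98 nM

Of the compounds shown here, two have been measured in an assay for inhibition of kynurenine 3-monooxygenase (Homo sapiens), read by mass spectrometry, with a stated time of 1 h; a higher number here means a weaker inhibitor, a lower number a stronger inhibitor. Compound 1 gives 3.16 nM, and compound 2 gives 3.98 nM. Compound 2 sits alongside compound 1, the two numbers within the usual scatter of each other, so neither can be called the stronger. Going by the values given here, the two also differ in more than one place, so no single step between them is known.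

Compound 3 `Cc1ccc([C@@H](C)Oc2cc3oc(=O)n(CCC(=O)O)c3cc2Cl)nc1` has not been measured. It differs from compound 2 in one place: 5-methylpyridin-2-yl in place of 4-methylpyridin-2-yl on a saturated chain carbon bound to an oxygen on an aromatic ring and a saturated chain carbon. Both methylpyridinyl groups appear among the measured compounds, and the measured numbers lie close together, so no shift beyond the scatter is expected for a 1.1-fold lower number from compound 2 to compound 3 (0.06 log units; within the scatter). For compound 3 in this assay the estimate is 3.5 nM, with a range from 1.5 nM to 8 nM.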

Compound 3, half-maximal inhibitory concentration: 3.16 nM
Estimate against measurement, compound 3: 1.1-fold (0.04 log units) above; the range from low to high includes it.
By their numbers in this assay, from the lowest: compounds 1, 3 and 2 (each within the scatter of the next).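

Placing 5-methylpyridin-2-yl in place of 4-methylpyridin-2-yl on the saturated chain carbon gives the first single-place comparison at this position in this assay (a 1.3-fold lower number from compound 2 to compound 3 (0.10 log units; within the scatter)). With the rest of the structure held the same, the two methylpyridinyl groups cannot be told apart in this assay, so compound 2 and compound 3 can be ranked in neither direction. Nothing available here explains why the two groups read alike.

The compounds shown leave open whether the pyridine needs a methyl group at all, since only methylpyridinyl groups appear, and whether an unsubstituted pyridin-2-yl or a chloropyridin-2-yl would read the same. They also leave open whether this swap would read alike on the core of compound 1, or with a tetrazole in place of the carboxylic acid.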